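The compounds below may be only part of what the source reports. "The series", "measured", "known", "first", "only" and "open" are said of these compounds alone.

Measured in a functional assay on the whole organism for inhibition, with Mus musculus as the target; a higher number here means that more compound is needed for the effect, a lower number that less compound is needed:
- compound 1 `CCCCOC(=O)Nc1cccc2c1CN(C)CC2c1ccccc1`: 4 mg/kg
- compound 2 `CN1Cc2c(NC(=O)OCc3ccccc3)cccc2C(c2ccccc2)C1`: about 15 mg/kg
- compound 3 `CCNCCC(=O)Nc1cccc2c1CN(C)CC2c1ccccc1`: > 200 mg/kg

The entry for compound 3 is a limit of this assay, not a number. It stands at the limit of > 200 mg/kg in this assay, at which 1 of the 3 values shown sits.

Compound 4 `CCCCNCCC(=O)Nc1cccc2c1CN(C)CC2c1ccccc1` turns the ethylamino group of compound 3 into butylamino: ethyl in place of hydrogen on a saturated chain carbon, two bonds along the chain from an amine nitrogen.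

Going by the values given here, no measured step makes this exact change. The large steps, an at least 50-fold higher number from compound 1 to compound 3 (1.69 log units; beyond the scatter) and an at least 13-fold higher number from compound 2 to compound 3 (1.12 log units; beyond the scatter), swap a whole group on the carbonyl carbon, which is a bigger edit. The closest in kind is a change at the end of a chain, a 3.8-fold higher number from compound 1 to compound 2 (0.57 log units; beyond the scatter), and it is modest.

A modest step towards a lower number is therefore expected, and another limit is quite possible. The expected step is an at least 2.0-fold lower number from compound 3 to compound 4 (0.30 log units; that floor lies within the scatter).

For compound 4 the estimated value is 100 mg/kg, with an expected range of 25 mg/kg to 300 mg/kg.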

Compound 4, dose for half-maximal effect: about 46 mg/kg
Compound 4: the middle estimate sits 2.2-fold (0.34 log units) above what was measured, within the range that was stated.
By their numbers in this assay, from the lowest: compound 1; then compound 2; then compound 4. At a limit, above all of these: compound 3.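

In this assay, compound 3 carries a limit of the assay rather than a number: the limit of > 200 mg/kg in this assay, at which 1 of the 4 values shown sits. Extending the end of the chain from ethylamino to butylamino gives a measurable value, with an at least 4.3-fold lower number from compound 3 to compound 4 (0.63 log units; beyond the scatter), so the result responds to a change at this chain end on the amine. Even so, the butylamino side chain does not match the benzyloxy or butoxy groups on the carbonyl carbon, with a 3.1-fold higher number from compound 2 to compound 4 (0.49 log units; beyond the scatter) and a 12-fold higher number from compound 1 to compound 4 (1.06 log units; beyond the scatter).

Ethylamino and butylamino alone cannot define a trend with chain length. On these data alone, it remains open whether a longer chain such as hexyl, or a benzyl or cyclohexyl group on the amine, would lower the number further or raise it again.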